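Alkynyl aryl swap on a shared thienopyridine core: compound 3

A few compounds are considered here, and "the series" means these few. Any claim that something is new, unique, unknown or untested is made for them only; others in the source may bear on it.

Measured so far in a functional assay on NCI-H460 cells (Homo sapiens) for inhibition, read by sulforhodamine B assay, with a stated time of 48 h; on this read-out lower numbers stand for stronger inhibition of growth and higher numbers for weaker inhibition of growth:
- compound 1, `COC(=O)c1sc2cc(C#Cc3cccc(N)c3)cnc2c1N`, compound 1 gives 11500 nM
- compound 2, `COC(=O)c1sc2cc(C#Cc3ccccc3F)cnc2c1N`, compound 2 gives > 150000 nM, which is a limit of the assay and not a number

Among the measured compounds shown here, only two compounds are in hand. Compound 1 carries a 3-aminophenyl on the triple-bonded carbon. Compound 2 carries a 2-fluorophenyl at the same place, and for compound 2 the read-out is a limit (the limit of > 150000 nM in this assay, at which 1 of the 2 values shown sits), so where it stands on the scale is known only as a bound. For the measured compounds named here, the single measured step, an at least 13-fold higher number from compound 1 to compound 2 (1.11 log units; beyond the scatter), is large and beyond the scatter.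

Compound 3, `COC(=O)c1sc2cc(C#Cc3ccsc3)cnc2c1N`, is not yet measured. It differs from compound 2 by thiophen-3-yl in place of 2-fluorophenyl on a triple-bonded carbon. Because an at least 13-fold higher number from compound 1 to compound 2 (1.11 log units; beyond the scatter) shows that the aryl on the triple-bonded carbon can shift the number strongly, the step to compound 3 may be sizeable in either direction; the thiophen-3-yl lacks the amino group of compound 1, so it is expected to sit nearer compound 2 than compound 1. Compound 3 is estimated at 100000 nM, within 20000 nM to 300000 nM. The expected step is an at least 1.5-fold lower number from compound 2 to compound 3 (0.17 log units; that floor lies within the scatter), and a limit is again quite possible.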

Compound 3, concentration for 50% growth inhibition: 24800 nM
Beside the measured number, compound 3's estimate is 4.0-fold (0.61 log units) above it; low and high end bracket the measured number.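

In this assay, the aryl on the triple-bonded carbon no longer divides simply into the 3-aminophenyl of compound 1 and everything else: thiophen-3-yl carries no amino group, yet it gives an at least 6.0-fold lower number from compound 2 to compound 3 (0.78 log units; beyond the scatter) and stays close to the 3-aminophenyl result, with a 2.2-fold higher number from compound 1 to compound 3 (0.33 log units; beyond the scatter). Compound 1 keeps the lower number, so this swap still costs something, but the amino group is evidently not what separates a measurable growth inhibition from none here, and a small five-membered aromatic ring with a sulfur atom is tolerated at this place. The size of the first step is only a floor, as compound 2 stands at a limit of the assay and not at a number: the limit of > 150000 nM in this assay, at which 1 of the 3 values shown sits.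

Compound 2 differs from compound 3 in both the ring and the fluorine, so the compounds shown cannot tell which of the two matters, and a plain phenyl on the triple-bonded carbon would separate them. On these data alone, whether an amine on the thiophene ring would add to what the thiophen-3-yl already gives, or whether a hydroxyl or a carboxylic acid on the phenyl ring could stand in for the amine, also remains open.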